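The source may hold more compounds than are shown below. What is called first, only, known or untested is meant among the compounds shown, and "the series" means these compounds.

In a functional assay on KBVIN cells (Homo sapiens) for cytotoxicity, read by sulforhodamine B assay (on this read-out higher numbers stand for weaker inhibition of growth and lower numbers for stronger inhibition of growth), compound 1 `Cc1ccc2c(c1)CCCN2c1nc(Cl)nc2ccccc12` gives 46 nM and compound 2 `Cc1ccc2c(c1)CCCN2c1nc(C)nc2ccccc12` gives 176 nM, so compound 2 holds the higher of the two numbers. Compound 3 `Cc1nc(N2CCCc3cc(Br)ccc32)c2ccccc2n1` differs from compound 2 at one place: bromo in place of methyl on an aromatic carbon. Among the compounds with values here, the only measured step, a 3.8-fold higher number from compound 1 to compound 2 (0.58 log units; beyond the scatter), is methyl in place of chloro on an aromatic carbon, modest in size and beyond the scatter. Within the data shown here, it lies at a different place in the molecule, so it bears on the new change only indirectly, and no measurement yet covers bromo at this place. A small shift towards a lower number in this assay is therefore expected, possibly no larger than the scatter. The estimated step is a 1.5-fold lower number from compound 2 to compound 3 (0.17 log units; within the scatter). For compound 3 the estimate is 120 nM, with an expected range of 40 nM to 350 nM.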

Compound 3, concentration for 50% growth inhibition: 169 nM
Beside the measured number, compound 3's estimate is 1.4-fold (0.15 log units) below it; low and high end bracket the measured number.
By their numbers in this assay, from the lowest: compound 1; then compounds 3 and 2 (each within the scatter of the next).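

At this aromatic carbon of the six-membered ring of carbon only, part of the fused system of two rings, bromo in place of methyl gives a 1.0-fold lower number from compound 2 to compound 3 (0.02 log units; within the scatter) in this assay and so leaves the read-out within the scatter. Within the data shown here, this is the first reading at this position: methyl and bromo are not told apart here, whereas the earlier step, a 3.8-fold higher number from compound 1 to compound 2 (0.58 log units; beyond the scatter), lay at a different place in the molecule and went beyond the scatter. No evidence at hand bears on why these two groups read alike at this carbon.

Open, from the compounds shown here alone, is how an amino group, a methoxy group or a carboxylic acid at this carbon would read in this assay on the same core. Also open, going by these compounds, is whether methyl and bromo still read alike here when chloro stands at the other changed place, as it does in compound 1.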